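Compound 2 to compound 3: 4-methoxyphenyl enters

This account rests on a few compounds, and the source may have more. Where it says the series, first, only, none or still open, it means among the compounds named here.

In a functional assay on G-361 cells (Homo sapiens) for cytotoxicity, read by fluorescence, with a stated time of 72 h (on this read-out higher numbers stand for weaker inhibition and lower numbers for stronger inhibition), compound 1 `CC(C)c1n[nH]c2c(NCc3ccc(-c4ccccn4)cc3)nc(N3CCNCC3)nc12` gives 64 nM and compound 2 `CC(C)c1n[nH]c2c(NCc3ccc(-c4ccccn4)cc3)nc(NCCN(C)C)nc12` gives 640 nM. Compound 2 therefore holds the higher of the two numbers, the weaker inhibition of the pair. For the measured compounds named here, the one measured step, a 10-fold higher number from compound 1 to compound 2 (1.00 log units; beyond the scatter), came with (2-(dimethylamino)ethyl)amino in place of piperazin-1-yl on an aromatic carbon.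

Compound 3 `COc1ccc(CNc2nc(NCc3ccc(-c4ccccn4)cc3)c3[nH]nc(C(C)C)c3n2)cc1` keeps the shared core of compound 2 and differs as follows: 4-methoxyphenyl in place of (dimethylamino)methyl on a saturated chain carbon bound to a nitrogen on an aromatic ring. In words, this is 4-methoxyphenyl in place of (dimethylamino)methyl on a saturated chain carbon bound to a nitrogen on an aromatic ring.

The measured step bears on this change only loosely, since it altered the same side chain but did not introduce 4-methoxyphenyl. Going by the values given here, no measured compound carries that group. Taking a 10-fold higher number from compound 1 to compound 2 (1.00 log units; beyond the scatter) as the only guide to size, a somewhat smaller move toward a higher number is expected, with wide uncertainty in both directions.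

The expected step is a 2.3-fold higher number from compound 2 to compound 3 (0.37 log units; beyond the scatter).

Compound 3 is estimated at 1500 nM, with an expected range of 300 nM to 7000 nM.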

Compound 3, half-maximal inhibitory concentration: 7490 nM
Beside the measured number, compound 3's estimate is 5.0-fold (0.70 log units) below it; the measured number lies above the stated range.
By their numbers in this assay, from the lowest: compound 1; then compound 2; then compound 3.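

In this assay, replacing (dimethylamino)methyl with 4-methoxyphenyl on the saturated chain carbon gives a 12-fold higher number from compound 2 to compound 3 (1.07 log units; beyond the scatter), so a side chain with an aromatic ring of carbon only and no amine nitrogen gives weaker inhibition than the amine-bearing (2-(dimethylamino)ethyl)amino chain. Against the piperazin-1-yl compound, the change to (4-methoxybenzyl)amino gives a 120-fold higher number from compound 1 to compound 3 (2.07 log units; beyond the scatter), which shows that this one place on the shared core can move the number over a wide span while the rest of the structure stays fixed. Nothing available explains why the number rises with this change.

Compound 3 changes two things at once, removing the dimethylamino nitrogen and adding the aromatic ring, so the compounds shown cannot say which of the two goes with the higher number. A 4-(dimethylamino)benzyl group would keep both the ring and an amine, a plain 2-methoxyethyl chain would have neither, and either would help separate the two, while a piperazine carrying a methyl on its outer nitrogen would test how much the ring amine of compound 1 can be altered.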